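Moving the Sulfur Within the Thiophene Ring

The compounds below may be only part of what the source reports. "The series", "measured", "known", "first", "only" and "open" are said of these compounds alone.

Going by the values given here, compound 2 `COc1ccc(-c2cc3ccccc3nc2/C=C/C(=O)c2cccs2)cc1` holds the lower of the two numbers measured so far: in a functional assay on NCI-H1299 cells (Homo sapiens) for antiproliferative activity, read by XTT assay, with a stated time of 72 h (a higher number here means a weaker inhibitor, a lower number a stronger inhibitor), compound 2 gives 720 nM. Among the compounds with values here, its only neighbour, compound 1 `COc1ccc(-c2cc3ccccc3nc2/C=C/C(=O)c2ccc(O)cc2)cc1`, gives 8970 nM in this assay, and the step of a 12-fold lower number from compound 1 to compound 2 (1.10 log units; beyond the scatter). Compound 3 `COc1ccc(-c2cc3ccccc3nc2/C=C/C(=O)c2ccsc2)cc1` differs from compound 2 in a single place: thiophen-3-yl in place of thiophen-2-yl on a carbonyl carbon. No measured step covers this exchange; the one step shown replaces a different group on the same carbonyl carbon, so it says nothing about how the two thiophene isomers compare. The change is therefore expected to stay within the scatter, a 1.3-fold higher number from compound 2 to compound 3 (0.10 log units; within the scatter). Compound 3 is estimated at 900 nM, with a range from 300 nM to 2700 nM.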

Compound 3, half-maximal inhibitory concentration: 1220 nM
Compound 3: middle estimate off by 1.4-fold (0.13 log units), on the low side; the measured number falls inside the stated range.
By their numbers in this assay, from the lowest: compounds 2 and 3 (each within the scatter of the next); then compound 1.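

In this assay the step of a 1.7-fold higher number from compound 2 to compound 3 (0.23 log units; within the scatter) shows that thiophen-2-yl and thiophen-3-yl cannot be told apart on this carbonyl carbon, so where the sulfur sits in the ring makes no measurable difference here. With a 7.4-fold lower number from compound 1 to compound 3 (0.87 log units; beyond the scatter) the second thiophene also stands clear of 4-hydroxyphenyl, as the first did. No evidence here explains these numbers. Still open is whether sulfur is needed at all, as the compounds shown do not say how a plain phenyl or a furan-2-yl ring would compare on this carbonyl carbon.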